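A few compounds are considered here, and "the series" means these few. Any claim that something is new, unique, unknown or untested is made for them only; others in the source may bear on it.

Measured compounds in an assay on isolated protein for inhibition of matrix metalloproteinase-9 (Homo sapiens); a higher number here means a weaker inhibitor, a lower number a stronger inhibitor:
- compound 1, `O=C(OCc1ccccc1)c1cccc(=O)[nH]1`: 69000 nM
- compound 2, `O=C(OC1CCC1)c1cccc(S)n1`: 137000 nM
- compound 3, `O=C(OCc1ccc(Cl)cc1)c1cccc(=O)[nH]1`: 68000 nM

Compound 3 stands level with the other two: its number lies inside the scatter of compound 1 and also inside the scatter of compound 2, so no ordering among the three is supported by these figures. Among the measured compounds shown here, compound 2 differs from compound 3 in more than one place and no single step connects them; their two values simply sit within the scatter of each other.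

Compound 4, `O=C(OCc1ccc(C(F)(F)F)cc1)c1cccc(=O)[nH]1`, is the next member. It differs from compound 3 as follows: trifluoromethyl in place of chloro on an aromatic carbon.

For the measured compounds named here, the only measured step that bears on this change is the one on the same aromatic carbon, a 1.0-fold lower number from compound 1 to compound 3 (0.01 log units; within the scatter), where replacing hydrogen with chloro left the number unchanged within the scatter. Going by the values given here, nothing measured so far speaks to trifluoromethyl at this position. On that basis the replacement of chloro by trifluoromethyl is expected to give no step beyond the scatter in this assay, in either direction. The estimated step of a 1.0-fold lower number from compound 3 to compound 4 (0.02 log units; within the scatter) is accordingly expected to remain small. Compound 4 is therefore estimated at 65000 nM, with an expected range from 25000 nM to 170000 nM.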

Compound 4, half-maximal inhibitory concentration: 101000 nM
Compound 4: middle estimate off by 1.6-fold (0.19 log units), on the low side, and the stated range covers the measured number.
By their numbers in this assay, from the lowest: compounds 3, 1, 4 and 2 (each within the scatter of the next).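

Notes on the series: in this assay the aromatic carbon para to a large group has now carried hydrogen, chloro and trifluoromethyl, and the two new steps, a 1.5-fold higher number from compound 3 to compound 4 (0.17 log units; within the scatter) and a 1.5-fold higher number from compound 1 to compound 4 (0.17 log units; within the scatter), both stay within the scatter. Compounds 1, 3 and 4 therefore cannot be ordered, and going from chloro with its 1 heavy atom to trifluoromethyl with its 4 heavy atoms does not separate compound 4 from compound 3 at this position, which a single chloro step could not show. No supporting measurement bears on why these values remain together.

Whether any group on this carbon can produce a step beyond the scatter remains open, since an amine, a carboxylic acid or a longer chain such as n-butyl is not among the compounds shown. Among the compounds shown here, also open is whether changes elsewhere in the molecule matter more, because compound 2 is linked to the others by no single-place step and so says nothing about any one change.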